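Spiro-piperidine benzyl swap and mean residence time in mice

This account rests on a few compounds, and the source may have more. Where it says the series, first, only, none or still open, it means among the compounds named here.

Compound 2 `O=c1nc(N2CCC3(CCN(Cc4ccc(C(F)(F)F)cc4)CC3)CC2)sc2c([N+](=O)[O-])cc(C(F)(F)F)cc12` was measured in an ADME assay on the whole organism (strain ICR) with Mus musculus as the target, read by HPLC, at a dose of 50 mg/kg by the oral route (on this read-out lower numbers stand for a shorter-lived compound and higher numbers for a longer-lived compound), and gave 6.07 h. Compound 1 `O=c1nc(N2CCN(CC3CCCCC3)CC2)sc2c([N+](=O)[O-])cc(C(F)(F)F)cc12` gave 3.73 h in this assay, a number within the scatter of compound 2, so the two cannot be told apart. Compound 3 `O=c1nc(N2CCC3(CCN(Cc4cccc(F)c4)CC3)CC2)sc2c([N+](=O)[O-])cc(C(F)(F)F)cc12` has not been measured; it differs from compound 2 in one place: 3-fluorophenyl in place of 4-(trifluoromethyl)phenyl on a saturated chain carbon bound to an amine nitrogen in a ring. Among the compounds with values here, no measured pair shows this change, so its effect is not known. Compound 3 is expected to give 4.5 h, with a range of 2.2 h to 9 h. That estimate means a step of a 1.3-fold lower number from compound 2 to compound 3 (0.13 log units; within the scatter), a modest decrease expected to stay within the scatter.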

Compound 3, mean residence time: 4.83 h
For compound 3 the middle estimate is 1.1-fold (0.03 log units) below the measured one; the measured number falls inside the stated range.
By their numbers in this assay, from the lowest: compounds 1, 3 and 2 (each within the scatter of the next).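

Within the data shown here, replacing 4-(trifluoromethyl)phenyl with 3-fluorophenyl on a saturated chain carbon bound to an amine nitrogen in a ring is the only single-place change read in this assay, and it gives a 1.3-fold lower number from compound 2 to compound 3 (0.10 log units; within the scatter). At this position, then, these two groups cannot be told apart, even though the entering group has fewer heavy atoms. No measurement here bears on why this is so.

Still open, as far as these compounds go, is whether a carboxylic acid or an amine on the phenyl ring, or a longer chain in place of the benzyl carbon, would give a step beyond the scatter in this assay.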